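A few compounds are considered here, and "the series" means these few. Any claim that something is new, unique, unknown or untested is made for them only; others in the source may bear on it.

Compound 1 `COCOc1cc(=O)oc2cc(OCc3cccc(Cl)c3)ccc12`: 100 nM
Compound 2 `CC(=O)c1cc(=O)oc2cc(OCc3cccc(Cl)c3)ccc12`: 39.8 nM

Of these two numbers from an assay on isolated protein (strain Sprague-Dawley) for inhibition of Amine oxidase [flavin-containing] B (Rattus norvegicus), read by spectrophotometry, with a stated time of 5 min (a higher number here means a weaker inhibitor, a lower number a stronger inhibitor), compound 2 has the lower one; compound 1 sits higher by a 2.5-fold lower number from compound 1 to compound 2 (0.40 log units; beyond the scatter), a modest step in which acetyl replaced methoxymethoxy on an aromatic carbon. Compound 3 `N#Cc1cc(=O)oc2cc(OCc3cccc(Cl)c3)ccc12` has not yet been measured in this assay. It differs from compound 2 by cyano in place of acetyl on an aromatic carbon. Going by the values given here, no measured step compares cyano with acetyl, so the only step available, a 2.5-fold lower number from compound 1 to compound 2 (0.40 log units; beyond the scatter), concerns a different pair of groups at that carbon and bears on the present change only loosely: it shows that swapping the group at this carbon can shift the number modestly, but gives no direction for cyano. The step from compound 2 to compound 3 is therefore expected to stay within the usual scatter, a 1.0-fold higher number from compound 2 to compound 3 (0.00 log units; within the scatter). For compound 3 the estimate in this assay is 40 nM, with a range from 13 nM to 130 nM.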

Compound 3, half-maximal inhibitory concentration: 102 nM
Beside the measured number, compound 3's estimate is 2.6-fold (0.41 log units) below it; low and high end bracket the measured number.
By their numbers in this assay, from the lowest: compound 2; then compounds 1 and 3 (each within the scatter of the next).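

In this assay this position now has a direct comparison of cyano with acetyl: the swap gives a 2.6-fold higher number from compound 2 to compound 3 (0.41 log units; beyond the scatter) and so gives up the gain that acetyl showed over methoxymethoxy. Putting cyano in place of methoxymethoxy gives a 1.0-fold higher number from compound 1 to compound 3 (0.01 log units; within the scatter) so these two groups cannot be told apart here, and acetyl alone stands out among the three groups tried at this aromatic carbon. Nothing available here explains why acetyl gives the lower number.

Three groups are too few to show which feature of acetyl matters. Still open, from the compounds shown here alone, is whether a longer ketone such as propionyl, a methyl ester, a primary amide or a carboxylic acid at this carbon would match compound 2 or go lower still.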